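A few compounds are considered here, and "the series" means these few. Any claim that something is new, unique, unknown or untested is made for them only; others in the source may bear on it.

Compound 1 `CC(C)c1onc(-c2c(Cl)cccc2Cl)c1COc1ccc(-c2ccc3cc(C(=O)O)ncc3c2)cc1` gives 77 nM in a functional assay on CV-1 cells for agonist activity at Bile acid receptor (Homo sapiens), read by a luciferase reporter; on this read-out lower numbers stand for an effect already at smaller amounts and higher numbers for an effect only at larger amounts of compound.
Compound 2 `CC(C)c1onc(-c2c(Cl)cccc2Cl)c1COc1ccc(-c2ccc3c(C(=O)O)nccc3c2)cc1` gives 190 nM in this assay.
Compound 3 `CCc1cc(C(=O)O)nc2ccc(-c3ccc(OCc4c(-c5c(Cl)cccc5Cl)noc4C(C)C)cc3)cc12` gives 32 nM in this assay.

Of the compounds shown here, three have been measured so far. They share one core, differing only in where the carboxy group and a small substituent sit on the two-ring system at one end. Of the three, compound 3 has the lowest number in this assay: compound 1 is next, and the gap between them lies beyond the usual scatter, while compound 2 lies furthest away, also beyond the scatter. Compound 3 is thus the most potent of the three on this read-out.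

Compound 4 `CCOc1cc(C(=O)O)nc2ccc(-c3ccc(OCc4c(-c5c(Cl)cccc5Cl)noc4C(C)C)cc3)cc12` is the next step from compound 3. The change is small: ethoxy in place of ethyl on an aromatic carbon. Within the data shown here, no measured pair shows what such an exchange does here, so the expectation rests on compound 3 alone and on the small size of the change. The step from compound 3 to compound 4 in this assay is expected to be modest, a 1.3-fold higher number from compound 3 to compound 4 (0.10 log units; within the scatter), most likely within the usual scatter, with a slight lean toward a higher number. Compound 4 is therefore expected to give about 40 nM in this assay, in the range from 15 nM to 110 nM.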

Compound 4, half-maximal effective concentration: 14 nM
Compound 4: middle estimate off by 2.9-fold (0.46 log units), on the high side; the measured number lies below the stated range.
By their numbers in this assay, from the lowest: compound 4; then compound 3; then compound 1; then compound 2.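

Putting ethoxy in place of ethyl on this aromatic carbon, opposite the ring nitrogen and meta to the carboxy group, gives a 2.3-fold lower number from compound 3 to compound 4 (0.36 log units; beyond the scatter) in this assay. Among these compounds, this is the first pair in the set that differs in only one place, so it is the first direct reading of what a change at this carbon does: the substituent here can grow from ethyl to ethoxy, gaining an oxygen that links it to the ring, and the number still falls, which means an effect at smaller amounts of compound. Nothing presented here explains why the number falls.

A single exchange cannot separate the contribution of the linking oxygen from that of the larger group, and methoxy, a longer chain such as propoxy, or an amine such as dimethylamino on the same carbon would each help to tell these apart. On these data alone, it also remains open whether ethoxy would give a similar step with the carboxy group placed as in compound 1 or compound 2, whose cores carry neither ethyl nor ethoxy.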